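Aryl exchange on the carbonyl: compound 3 to compound 4

The compounds below may be only part of what the source reports. "The series", "measured", "known", "first", "only" and "open" are said of these compounds alone.

The series shares one core and differs only in the aryl group on the carbonyl carbon whose other neighbour is an amide-type nitrogen. Compound 1 `CN(C(=O)NC(=O)c1ccc(F)c(F)c1)c1nc(C(F)(F)F)c(C(=O)N/N=C/c2ccccc2C(F)(F)F)s1` gives 3.66 ug/mL in a functional assay on BCG823 cells (Homo sapiens) for inhibition, read by MTT assay, with a stated time of 72 h; a lower number here means a stronger inhibitor, a higher number a weaker inhibitor; compound 2 `CN(C(=O)NC(=O)c1ccc(Cl)cc1Cl)c1nc(C(F)(F)F)c(C(=O)N/N=C/c2ccccc2C(F)(F)F)s1` gives 5.73 ug/mL in this assay; compound 3 `CN(C(=O)NC(=O)c1c(Cl)cccc1Cl)c1nc(C(F)(F)F)c(C(=O)N/N=C/c2ccccc2C(F)(F)F)s1` gives 4.12 ug/mL in this assay. Compound 3 holds the second highest of the three numbers, and both of its neighbours sit within the scatter: a 1.1-fold higher number from compound 1 to compound 3 (0.05 log units; within the scatter) and a 1.4-fold lower number from compound 2 to compound 3 (0.14 log units; within the scatter); the remaining pair likewise, a 1.6-fold higher number from compound 1 to compound 2 (0.19 log units; within the scatter). Compound 4 `CN(C(=O)NC(=O)c1ccccc1F)c1nc(C(F)(F)F)c(C(=O)N/N=C/c2ccccc2C(F)(F)F)s1` carries the change (2-fluorophenyl in place of 2,6-dichlorophenyl on a carbonyl carbon). Every measured step is an exchange of one phenyl bearing chlorine or fluorine for another at this same carbonyl carbon, and none of them moved the number beyond the scatter, so the step from compound 3 to compound 4 is expected to stay within the scatter as well, with no direction claimed: a 1.0-fold higher number from compound 3 to compound 4 (0.01 log units; within the scatter). Compound 4 is accordingly estimated at 4.2 ug/mL in this assay, with a range of 2.1 ug/mL to 8.4 ug/mL.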

Compound 4, half-maximal inhibitory concentration: 4.67 ug/mL
For compound 4 the middle estimate is 1.1-fold (0.05 log units) below the measured one; measured number inside the range.
By their numbers in this assay, from the lowest: compounds 1, 3, 4 and 2 (each within the scatter of the next).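

Exchanging 2,6-dichlorophenyl for 2-fluorophenyl on the carbonyl carbon gives, in this assay, a 1.1-fold higher number from compound 3 to compound 4 (0.05 log units; within the scatter). Against the other two aryl groups the result is the same, with a 1.2-fold lower number from compound 2 to compound 4 (0.09 log units; within the scatter) and a 1.3-fold higher number from compound 1 to compound 4 (0.11 log units; within the scatter), so across these four compounds the number does not separate a phenyl bearing 1 fluorine and no chlorine from the dichlorophenyl and difluorophenyl groups. No measurement is available that bears on why these exchanges stay within the scatter.

From the compounds shown here alone, every group at this position is a phenyl bearing chlorine or fluorine, so it remains open how an unsubstituted phenyl, a methoxyphenyl or a cyclohexyl would read here. Also open, going by these compounds, is whether an aryl group carrying an amine or a carboxylic acid would move the number beyond the scatter.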